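The compounds below may be only part of what the source reports. "The series", "measured", "known", "first", "only" and "open" are said of these compounds alone.

Measured so far in a functional assay on A549 cells (Homo sapiens) for antiproliferative activity, read by MTT assay, with a stated time of 72 h; a lower number here means a stronger inhibitor, a higher number a weaker inhibitor:
- compound 1 `CCOC1=C(C(=O)c2ccccc2)C(c2ccc(Br)cc2)N(CCCn2ccnc2)C1=O` gives 35300 nM
- compound 2 `CC(C)OC1=C(C(=O)c2ccccc2)C(c2ccc(Br)cc2)N(CCCn2ccnc2)C1=O` gives 8720 nM
- compound 3 `NC1=C(C(=O)c2ccccc2)C(c2ccc(Br)cc2)N(CCCn2ccnc2)C1=O` gives no number and was reported as "not active" (no number reported)

Compound 3 thus stands outside the numbers shown: compound 1 and compound 2, which carry an alkoxy group where compound 3 carries an amino group, each produced a weak but measurable inhibition, whereas compound 3 produced none that could be quantified in this assay. Compound 4 `O=C(C1=C(Nc2ccc(F)cc2)C(=O)N(CCCn2ccnc2)C1c1ccc(Br)cc1)c1ccccc1` differs from compound 3 in one place: 4-fluorophenyl in place of hydrogen on an amine nitrogen. For the measured compounds named here, only one measured step exists, a 4.0-fold lower number from compound 1 to compound 2 (0.61 log units; beyond the scatter), and it concerns the alkoxy chain, not the amine nitrogen; no measured step speaks to the change from compound 3 to compound 4. The expectation therefore rests on little more than the observation that the substituted analogues, compound 1 and compound 2, returned numbers at all while the bare amine did not, so compound 4 may return a weak number, or may again fall outside what this assay can quantify. Compound 4 is estimated at 15000 nM, with an expected range from 3000 nM to 60000 nM.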

Compound 4, half-maximal inhibitory concentration: 27400 nM
Beside the measured number, compound 4's estimate is 1.8-fold (0.26 log units) below it, within the range that was stated.
By their numbers in this assay, from the lowest: compound 2; then compounds 4 and 1 (each within the scatter of the next).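

With (4-fluorophenyl)amino on the double-bonded ring carbon, compound 4 returns a number in this assay, so a substituted amine here can give measurable inhibition, though the change from compound 3 cannot be read as a size because compound 3 has no number. Replacing ethoxy gives a 1.3-fold lower number from compound 1 to compound 4 (0.11 log units; within the scatter) and so separates the two groups by no more than the scatter, while replacing isopropoxy gives a 3.1-fold higher number from compound 2 to compound 4 (0.50 log units; beyond the scatter) and leaves compound 2 with the lowest number of the measured compounds. No evidence is available to explain these differences.

The compounds shown leave open whether the fluorine or the ring itself accounts for the measurable number, which phenylamino or the smaller methylamino would help to separate. They also leave open whether any group on this carbon can go lower than isopropoxy does in compound 2.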